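A few compounds are considered here, and "the series" means these few. Any claim that something is new, unique, unknown or untested is made for them only; others in the source may bear on it.

Compound 1 `C=C1CC[C@@H]2[C@](C)(COC(C)=O)[C@H](OC(C)=O)CC[C@@]2(C)[C@H]1CC(Nc1ccc(S(=O)(=O)Nc2cc(C)on2)cc1)C1=CCOC1=O` stands at the lowest of the two numbers seen here, giving 6390 nM in a functional assay on MOLT-4 cells (Homo sapiens) for inhibition, read by sulforhodamine B assay, with a stated time of 48 h; a lower number here means a stronger inhibitor of growth, a higher number a weaker inhibitor of growth. Compound 2 `C=C1CC[C@@H]2[C@](C)(COC(C)=O)[C@H](OC(C)=O)CC[C@@]2(C)[C@H]1CC(Nc1ccc(S(=O)(=O)Nc2nccc(C)n2)cc1)C1=CCOC1=O` gives 17900 nM in this assay, and the step of a 2.8-fold higher number from compound 1 to compound 2 (0.45 log units; beyond the scatter) came from exchanging the ring on the sulfonamide nitrogen. Compound 3 `C=C1CC[C@@H]2[C@](C)(COC(C)=O)[C@H](OC(C)=O)CC[C@@]2(C)[C@H]1CC(Nc1ccc(S(=O)(=O)Nc2nccs2)cc1)C1=CCOC1=O` differs from compound 1 in that same place: 1,3-thiazol-2-yl in place of 5-methyl-1,2-oxazol-3-yl on a sulfonamide nitrogen. Within the data shown here, the only step that bears on this, the one from compound 1 to compound 2, was a modest rise. A second ring exchange on the same nitrogen is therefore expected to shift the number only modestly, most likely upward, as a 1.5-fold higher number from compound 1 to compound 3 (0.17 log units; within the scatter). Compound 3 is thus estimated at 9500 nM, within a range of 4000 nM to 22000 nM.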

Compound 3, concentration for total growth inhibition: 73200 nM
Compound 3: the middle estimate sits 7.7-fold (0.89 log units) below what was measured; the whole stated range lies below it.
By their numbers in this assay, from the lowest: compound 1; then compound 2; then compound 3.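

The ring on the sulfonamide nitrogen can matter far more than the first exchange suggested: an 11-fold higher number from compound 1 to compound 3 (1.06 log units; beyond the scatter) is a large step, and a 4.1-fold higher number from compound 2 to compound 3 (0.61 log units; beyond the scatter) shows that 1,3-thiazol-2-yl also gives a weaker result than 4-methylpyrimidin-2-yl. Although 5-methyl-1,2-oxazol-3-yl and 1,3-thiazol-2-yl are both five-membered aromatic rings with two hetero atoms, that shared description does not predict similar numbers. No measurement available here explains the gap.

From the compounds shown here alone, whether a phenyl or pyridin-2-yl ring on this nitrogen would fall nearer compound 1 or compound 3 remains open.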